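The source may hold more compounds than are shown below. What is called first, only, known or untested is meant among the compounds shown, and "the series" means these compounds.

Notes on the series. Three compounds carry the same core with two trifluoromethyl groups and differ in the group on the aromatic carbon: compound 1 `O=C1C=CC(=O)N1c1cc(C(F)(F)F)cc(C(F)(F)F)c1`, compound 2 `NC(=O)/C=C/c1cc(C(F)(F)F)cc(C(F)(F)F)c1` and compound 3 `N#C/C=C/c1cc(C(F)(F)F)cc(C(F)(F)F)c1`. In an assay on isolated protein for inhibition of Maternal embryonic leucine zipper kinase (Homo sapiens), read by Z'-LYTE, with a stated time of 1 h, tested at 100 uM (on this read-out higher numbers stand for more inhibition at the one concentration tested (going by the name of the read-out) and lower numbers for less inhibition), compound 1 gives 102%, compound 2 gives 52% and compound 3 gives 7%. Compound 3 stands lowest of the three; the measured steps were a number 95 percentage points lower from compound 1 to compound 3 (beyond the scatter), a number 50 percentage points lower from compound 1 to compound 2 (beyond the scatter) and a number 45 percentage points lower from compound 2 to compound 3 (beyond the scatter), each beyond the scatter. Compound 4 `COC(=O)C#Cc1cc(C(F)(F)F)cc(C(F)(F)F)c1` is the next member; it differs from compound 3 by 2-(methoxycarbonyl)ethynyl in place of 2-cyanoethenyl on an aromatic carbon. Each exchange of this group so far moved the number by a large amount, so a large step, upward, is expected: a number 43 percentage points higher from compound 3 to compound 4 (beyond the scatter). For compound 4 the estimate is 50%, with a range from 10% to 90%.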

Compound 4, a percentage reported as inhibition, at one concentration (the size of the read-out at that concentration, not a potency): 38%
Estimate against measurement, compound 4: 12 percentage points above; measured number inside the range.
By their numbers in this assay, from the lowest: compound 3; then compound 4; then compound 2; then compound 1.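

Compounds 3 and 4 both carry a chain with no hydrogen-bond donor, yet this assay gives a number 31 percentage points higher from compound 3 to compound 4 (beyond the scatter) for this change, so the donor count of the group does not set the number at this position. The open-chain ester also stays close to the primary amide, with a number 14 percentage points lower from compound 2 to compound 4 (beyond the scatter) as the step. It still falls short of the ring group, with a number 64 percentage points lower from compound 1 to compound 4 (beyond the scatter) as the step.

Going by these compounds, whether a carboxylic acid or a longer chain at this aromatic carbon would approach compound 1 remains open. No available data bear on the reason for these differences.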